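The compounds below may be only part of what the source reports. "The series", "measured", "known", "first", "only" and "open" are said of these compounds alone.

Working notes on the series. Compound 1 `COc1ccc2cc(CO)oc(=O)c2c1` carries a methoxy group on its aromatic part; in a functional assay on NCI/ADR-RES cells (Homo sapiens) for antiproliferative activity, read by sulforhodamine B assay, with a stated time of 48 h (on this read-out higher numbers stand for weaker inhibition of growth and lower numbers for stronger inhibition of growth), compound 1 gives 160 ug/mL. Compound 2 `COc1ccc2cc(CCCOCCCc3cccnc3)oc(=O)c2c1` carries the same methoxy group together with a longer side chain; in this assay compound 2 gives 19.3 ug/mL. Compound 3 `O=C1OC(CO)Cc2ccccc21` has a partly saturated core and no methoxy group. In this assay compound 3 reaches only a limit of the assay, >= 250 ug/mL. Compound 3 therefore stands at the limit of >= 250 ug/mL in this assay, at which 1 of the 3 values shown sits, with no number of its own to place it among the others. Compound 4 `COc1ccc2c(c1)C(=O)OC(CO)C2` differs from compound 3 by methoxy in place of hydrogen on an aromatic carbon. Within the data shown here, no step between two measured compounds follows this change, so its size cannot be read from the measured pairs. The step of an at least 1.2-fold lower number from compound 3 to compound 4 (0.09 log units; that floor lies within the scatter) is expected to be small, toward stronger inhibition if anything, because compound 1, which also carries a methoxy group, gives 160 ug/mL. Compound 4 is expected to give about 200 ug/mL, within 80 ug/mL to 300 ug/mL, with a real chance that only a limit is reported.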

Compound 4, concentration for 50% growth inhibition: >= 250 ug/mL
Compound 4 was reported as a limit; the forecaster's own chance of this, stated with the estimate: 45%; middle value at least 1.2-fold (0.09 log units) from the limit.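

No step can be read from compound 3 to compound 4, because in this assay both stand only at a limit, not a number: the limit of >= 250 ug/mL in this assay, at which 2 of the 4 values shown sit.

The compounds shown leave open how far methoxy in place of hydrogen on an aromatic carbon shifts growth inhibition on this partly saturated core.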